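Moving one chlorine on the benzoic acid ring

A few compounds are considered here, and "the series" means these few. Any claim that something is new, unique, unknown or untested is made for them only; others in the source may bear on it.

compound 1 `Cc1c(OCCCCOc2ccc(C(=O)O)cc2Cl)ccc(C(=O)CC2CCCC2)c1O` gives 21%
compound 2 `Cc1c(OCCCCOc2ccc(C(=O)O)cc2Cl)ccc(C(=O)CC(C)C)c1O` gives 61%
compound 3 `Cc1ccc(C(=O)O)cc1OCCCCOc1ccc(C(=O)CC(C)C)c(O)c1C` gives 21%

In an ADME assay (liver) for metabolic stability, with Liver microsome (Rattus norvegicus) as the target, read by LC-MS, using microsomes and NADPH, with stated times of 5 min and 60 min, tested at 4 uM (on this read-out higher numbers stand for a more stable compound and lower numbers for a less stable compound), compound 1 gives 21% and stands level with compound 3, while compound 2 stands clearly higher. Compound 4 `Cc1c(OCCCCOc2ccc(C(=O)O)c(Cl)c2)ccc(C(=O)CC2CCCC2)c1O` has the same atoms as compound 1, joined differently: 4-carboxy-3-chlorophenyl in place of 4-carboxy-2-chlorophenyl on an oxygen on a saturated carbon. The 4-carboxy-3-chlorophenyl group enters in place of 4-carboxy-2-chlorophenyl on an oxygen on a saturated carbon. Going by the values given here, no measured step makes this exact change. The nearest is a number 40 percentage points lower from compound 2 to compound 3 (beyond the scatter), a large step at the same place, but with a different group entering. The equally large a number 40 percentage points higher from compound 1 to compound 2 (beyond the scatter) concerns the cyclopentyl group, which compound 4 keeps. The expected result is a number 4 percentage points higher from compound 1 to compound 4 (within the scatter), with real uncertainty in both directions. Compound 4 is estimated at 25% (8% to 50%).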

Compound 4, percent of the compound remaining: 67%
Beside the measured number, compound 4's estimate is 42 percentage points below it; measured number above the stated range.
By their numbers in this assay, from the lowest: compounds 1 and 3 (each within the scatter of the next); then compounds 2 and 4 (each within the scatter of the next).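

The change to 4-carboxy-3-chlorophenyl brings a number 46 percentage points higher from compound 1 to compound 4 (beyond the scatter) in this assay. The two groups have the same atoms, so at this place, on an oxygen on a saturated carbon, the arrangement of atoms on the ring alone separates compound 1 from compound 4. Nothing available gives a reason for this difference.

Open, on these data alone, is whether the same change would carry over with the isopropyl group of compound 2. Also open, as far as these compounds go, is what a fluorine in place of the chlorine would give.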